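The source may report more compounds than this note shows. Statements on the series, on what has been measured and on what is new or still open speak of the compounds shown alone.

Values in a functional assay on HepG2 cells (Homo sapiens) for antiproliferative activity, read by MTT assay, with a stated time of 24 h (a higher number here means a weaker inhibitor, a lower number a stronger inhibitor), so far:
compound 1 (`FC(F)(F)c1ccc(-c2nn(-c3ccccc3)cc2-c2nc3ccccc3[nH]2)cc1`) gives 6030 nM
compound 2 (`COc1ccc(S(=O)(=O)n2c(-c3cn(-c4ccccc4)nc3-c3ccc(C(F)(F)F)cc3)nc3ccccc32)cc1`) gives 370 nM

Compound 2 holds the lower of these two numbers in this assay and is the stronger of the pair. Setting (4-methoxyphenyl)sulfonyl in place of hydrogen on an aromatic nitrogen gave a 16-fold lower number from compound 1 to compound 2 (1.21 log units; beyond the scatter) and this large step is the only measured one that bears on what follows. Compound 3 (`O=S(=O)(c1ccc(Cl)cc1)n1c(-c2cn(-c3ccccc3)nc2-c2ccc(C(F)(F)F)cc2)nc2ccccc21`) carries chloro in place of methoxy on an aromatic carbon, para to a large group (chloro in place of methoxy on an aromatic carbon). For the measured compounds named here, the large step brought in the whole sulfonyl group, so it does not isolate the methoxy, and no measured pair changes that group alone. The data set no direction, and only a small change is expected: a 1.1-fold higher number from compound 2 to compound 3 (0.03 log units; within the scatter) is the estimate, within the scatter. For compound 3 the estimated value is 400 nM with an expected range (150 nM to 1100 nM).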

Compound 3, half-maximal inhibitory concentration: 3930 nM
Compound 3: middle estimate off by 9.8-fold (0.99 log units), on the low side, outside the stated range (above it).
By their numbers in this assay, from the lowest: compound 2; then compounds 3 and 1 (each within the scatter of the next).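

Chloro in place of methoxy on this aromatic carbon, para to a large group, gave an 11-fold higher number from compound 2 to compound 3 (1.03 log units; beyond the scatter) and so shows that this single substituent decides much of what the sulfonyl group brings. With (4-chlorophenyl)sulfonyl on the aromatic nitrogen the result was a 1.5-fold lower number from compound 1 to compound 3 (0.19 log units; within the scatter) and so the large step seen earlier belongs to the (4-methoxyphenyl)sulfonyl group, not to any arylsulfonyl group placed there. Nothing measured here explains why methoxy and chloro differ so widely at this position.

The compounds shown leave open whether methoxy is special or chloro alone is poor, since hydroxy, ethoxy, fluoro or a dimethylamino group on the same carbon would separate those readings. They also leave open how much depends on the sulfonyl link itself, which a carbonyl in its place would test.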